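The source may report more compounds than this note shows. Statements on the series, on what has been measured and on what is new or still open speak of the compounds shown alone.

Of the compounds shown here, three built on one shared core have been measured in a functional assay for inhibition of sodium/hydrogen exchanger (Oryctolagus cuniculus); on this read-out higher numbers stand for weaker inhibition and lower numbers for stronger inhibition. Compound 1 `CCCc1cc(C)c(C(=O)N=C(N)N)cc1S(C)(=O)=O` gives 5.7 nM. Compound 2 `CCSc1cc(C)c(C(=O)N=C(N)N)cc1S(C)(=O)=O` gives 5.9 nM, and the step of a 1.0-fold higher number from compound 1 to compound 2 (0.01 log units; within the scatter) shows the two as indistinguishable. Compound 3 `Cc1cc(OC(C)C)c(S(C)(=O)=O)cc1C(=O)N=C(N)N` gives 19 nM, the highest number of the three; because the steps of a 3.3-fold higher number from compound 1 to compound 3 (0.52 log units; beyond the scatter) and a 3.2-fold higher number from compound 2 to compound 3 (0.51 log units; beyond the scatter) both lie beyond the scatter, compound 3 is the weakest inhibitor among those measured.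

Compound 4 `Cc1cc(-n2cccn2)c(S(C)(=O)=O)cc1C(=O)N=C(N)N` differs from compound 3 in one place: 1H-pyrazol-1-yl in place of isopropoxy on an aromatic carbon. Going by the values given here, no measured step exchanges a chain-linked group for an aromatic ring at this position, so the expectation rests only on what the measured steps show around it. Those steps indicate that the isopropoxy group at this position gave a modestly higher number than either of the two other substituents tried there, while the two of those substituents were equivalent to each other. Whether a pyrazolyl ring behaves more like the isopropoxy group or more like the other two cannot be read from these data, so a step in either direction is possible. On balance the number for compound 4 is expected to fall close to that of compound 3, with a 1.4-fold lower number from compound 3 to compound 4 (0.13 log units; within the scatter) as the likeliest outcome. Compound 4 is therefore estimated at 14 nM, within a range from 4 nM to 50 nM.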

Compound 4, half-maximal inhibitory concentration: 25 nM
Beside the measured number, compound 4's estimate is 1.8-fold (0.25 log units) below it, within the range that was stated.
By their numbers in this assay, from the lowest: compounds 1 and 2 (each within the scatter of the next); then compounds 3 and 4 (each within the scatter of the next).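

In this assay, the only ring among the four groups tried at this position does not separate from the isopropoxy group: a 1.3-fold higher number from compound 3 to compound 4 (0.12 log units; within the scatter) stays within the scatter, although a five-membered aromatic ring replaces a group with no ring. Against the other two substituents, the new group shows a modest gap of the kind already seen for isopropoxy, with a 4.2-fold higher number from compound 2 to compound 4 (0.63 log units; beyond the scatter) and a 4.4-fold higher number from compound 1 to compound 4 (0.64 log units; beyond the scatter) both beyond the scatter, so the compounds now form two groups, compounds 1 and 2 with the lower numbers and compounds 3 and 4 with the higher ones. Nothing available explains this division of the four groups at this position, which remains an observation from the numbers alone.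

The compounds shown leave open whether the result for 1H-pyrazol-1-yl extends to other rings on this aromatic carbon, such as a phenyl, an imidazolyl or a saturated piperidine. They also leave open where an amine such as dimethylamino, a methoxy group or a longer chain such as butyl would fall relative to these two groups.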